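Furan Amide to Fluorophenyl Amide on a Shared Core

The source may report more compounds than this note shows. Statements on the series, on what has been measured and on what is new or still open speak of the compounds shown alone.

Compound 1 `CN1CCC(C(=O)N2Cc3c(NC(=O)c4ccco4)n[nH]c3C2(C)C)CC1` gives in a functional assay on A2780 cells (Homo sapiens) for antiproliferative activity, read by fluorescence, with a stated time of 72 h (on this read-out lower numbers stand for stronger inhibition and higher numbers for weaker inhibition), only a limit of > 5000 nM, so its standing on the numbers shown is the limit of > 5000 nM in this assay, at which 1 of the 2 values shown sits. A second member of the series, compound 2 `CC(C)CC(=O)Nc1n[nH]c2c1CN(C(=O)C1CCN(C3CC3)CC1)C2(C)C`, reaches 320 nM in this assay, which shows that the shared core can carry measurable activity. Compound 3 `CN1CCC(C(=O)N2Cc3c(NC(=O)c4cccc(F)c4)n[nH]c3C2(C)C)CC1` differs from compound 1 in one place: 3-fluorophenyl in place of furan-2-yl on a carbonyl carbon. Within the data shown here, no measured pair shows this change directly, and compound 1 itself returned only a limit of > 5000 nM, so the direction of the step is not anchored by a known number. The step of an at least 2.5-fold lower number from compound 1 to compound 3 (0.39 log units; beyond the scatter) is expected to be a moderate gain, though it may prove no larger than the usual scatter. Compound 3 is accordingly estimated at 2000 nM, with a range from 300 nM to 8000 nM.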

Compound 3, half-maximal inhibitory concentration: 200 nM
Compound 3: the middle estimate sits 10-fold (1.00 log units) above what was measured; measured number outside the range, below it.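

In this assay, this carbonyl position turns out to be sensitive to the group it carries: with the rest of the molecule held constant, 3-fluorophenyl in place of furan-2-yl gives an at least 25-fold lower number from compound 1 to compound 3 (1.39 log units; beyond the scatter). Among these compounds, this is the first single-place comparison, and it shows that this one change is enough to move a compound from no measured potency to a measured value. Compound 1 stands at a limit and not at a number, so the step marks only the smallest possible gain and its true size stays open: the limit of > 5000 nM in this assay, at which 1 of the 3 values shown sits.

The compounds shown do not separate the contribution of the fluorine from that of the six-membered aromatic ring, a question that an unsubstituted phenyl or a 3-chlorophenyl on this carbonyl carbon could address. From the compounds shown here alone, how a phenyl ring carrying an amine or a carboxylic acid would fare at this position also remains open.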